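The source may hold more compounds than are shown below. What is called first, only, known or untested is meant among the compounds shown, and "the series" means these compounds.

Three compounds share one core. In an assay on CHO cells for displacement of a labelled ligand from 5-hydroxytryptamine receptor 1D (Homo sapiens) (a higher number here means a weaker inhibitor, a lower number a stronger inhibitor), compound 1 `c1ccc(CNC2CCN(CCCc3c[nH]c4ccc(-n5cnnc5)cc34)CC2)cc1` gives 4.6 nM and compound 2 `CC(C)=CCCN(C)C1CCN(CCCc2c[nH]c3ccc(-n4cnnc4)cc23)CC1` gives 2.6 nM, while compound 3 `c1cncc(CNC2CCN(CCCc3c[nH]c4ccc(-n5cnnc5)cc34)CC2)c1` gives 35 nM, the highest number of the three and so the weakest binder shown. The step of a 7.6-fold higher number from compound 1 to compound 3 (0.88 log units; beyond the scatter) came with pyridin-3-yl in place of phenyl on a saturated chain carbon bound to an amine nitrogen. Compound 4 `c1cc(CNC2CCN(CCCc3c[nH]c4ccc(-n5cnnc5)cc34)CC2)co1` alters that same place again: furan-3-yl in place of pyridin-3-yl on a saturated chain carbon bound to an amine nitrogen. Going by the values given here, only that one measured step bears on this change, and it was modest. Because compound 1 gave 4.6 nM with phenyl there, compound 4 is expected to fall between the two, an expected step of a 2.9-fold lower number from compound 3 to compound 4 (0.46 log units; beyond the scatter). The estimate for compound 4 is 12 nM, within 4 nM to 40 nM.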

Compound 4, half-maximal inhibitory concentration: 4.5 nM
Estimate against measurement, compound 4: 2.7-fold (0.43 log units) above, and the stated range covers the measured number.
By their numbers in this assay, from the lowest: compounds 2, 4 and 1 (each within the scatter of the next); then compound 3.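

In this assay, furan-3-yl in place of pyridin-3-yl gives a 7.8-fold lower number from compound 3 to compound 4 (0.89 log units; beyond the scatter) and so recovers the loss, showing that not every aromatic ring with one hetero atom suffers it at this place. Furan-3-yl and phenyl cannot be told apart here (a 1.0-fold lower number from compound 1 to compound 4 (0.01 log units; within the scatter)), so the five-membered ring serves as well as the six-membered one. The whole ((furan-3-yl)methyl)amino group also stays level with the methyl(4-methylpent-3-en-1-yl)amino group (a 1.7-fold higher number from compound 2 to compound 4 (0.24 log units; within the scatter)).

On these data alone, whether thiophen-3-yl or pyridin-4-yl would follow furan-3-yl or pyridin-3-yl remains open. Nothing shown gives a reason for the gap between these rings.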